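The source may report more compounds than this note shows. Statements on the series, on what has been measured and on what is new or still open speak of the compounds shown alone.

In a functional assay on HL-60 cells (Homo sapiens) for antiproliferative activity, read by MTT assay, with a stated time of 48 h (on this read-out lower numbers stand for stronger inhibition and higher numbers for weaker inhibition), compound 1 `CC(=O)OC/C1=C/C[C@](C)(CCC=C(C)C)/C=C/[C@@H](OC(=O)C=C(C)C)[C@](C)(OC(C)=O)/C=C/C1=O` gives 3480 nM and compound 2 `CC(=O)O[C@]1(C)/C=C/C(=O)/C(CO)=C\C[C@](C)(CCC=C(C)C)/C=C/[C@H]1OC(=O)C=C(C)C` gives 2370 nM, while compound 3 `CC(C)=CCC[C@]1(C)/C=C/[C@@H](OC(=O)C=C(C)C)[C@](C)(O)/C=C/C(=O)/C(CN(C)C)=C\C1` gives 140 nM, the lowest number of the three. The next change, to compound 4 `CC(C)=CCC[C@]1(C)/C=C/[C@@H](OC(=O)C=C(C)C)[C@](C)(O)/C=C/C(=O)/C(C[Si](C)(C)C(C)(C)C)=C\C1`, removes the dimethylamino group of compound 3: a group of 7 heavy atoms (6 carbon, 1 silicon; no ring) in place of a group of 3 heavy atoms (2 carbon, 1 nitrogen; no ring), on a saturated chain carbon bound to a double-bonded ring carbon. It lies on a saturated chain carbon bound to a double-bonded ring carbon.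

Within the data shown here, the only measured step, a 1.5-fold lower number from compound 1 to compound 2 (0.17 log units; within the scatter), stays within the scatter and involves a different exchange, so it gives no direct measure of this one. The nearest guide is indirect. Neither compound 1 at 3480 nM nor compound 2 at 2370 nM carries the dimethylamino group, and both have higher numbers than compound 3, although they also differ from it elsewhere. A rise beyond the scatter, towards weaker inhibition, is therefore expected, but a partial one, with an estimated size of a 6.4-fold higher number from compound 3 to compound 4 (0.81 log units; beyond the scatter). The estimate for compound 4 is 900 nM, with an expected range of 250 nM to 3500 nM.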

Compound 4, half-maximal inhibitory concentration: 2770 nM
For compound 4 the middle estimate is 3.1-fold (0.49 log units) below the measured one, and the stated range covers the measured number.
By their numbers in this assay, from the lowest: compound 3; then compounds 2, 4 and 1 (each within the scatter of the next).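

In this assay, putting the group of 7 heavy atoms (6 carbon, 1 silicon) in place of the dimethylamino group gives a 20-fold higher number from compound 3 to compound 4 (1.30 log units; beyond the scatter), on a saturated chain carbon bound to a double-bonded ring carbon. Among these compounds, this is the first measure of a change at this position alone, since compounds 1 and 2 differ from compound 3 in more than one place, and it shows that this single exchange, with the rest of the molecule unchanged, is enough to produce a large step. No measurement at hand explains why the step is this large.

With only these two groups compared at this position, the compounds shown cannot separate the loss of the nitrogen from the change in the size of the group. As far as these compounds go, how a primary amine, a diethylamino group or an all-carbon tert-butyl group would compare at this place remains open.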